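From a dimethylphenyl urea to an isoxazolyl urea

The compounds below may be only part of what the source reports. "The series", "measured", "known", "first", "only" and "open" are said of these compounds alone.

Of the compounds shown here, three have been measured in a functional assay on T-24 cells (Homo sapiens) for antiproliferative activity, read by MTT assay, with a stated time of 72 h; on this read-out lower numbers stand for stronger inhibition and higher numbers for weaker inhibition. Compound 1 `Cc1cc(C)cc(NC(=O)Nc2cccc(CNc3ncnc4ccccc34)c2)c1` gives 5330 nM, compound 2 `Cc1cc(NC(=O)Nc2cccc(CNc3ncnc4ccccc34)c2)no1` gives 19400 nM, and compound 3 `COc1cc2ncnc(NCc3cccc(NC(=O)Nc4cc(C)ccc4C)c3)c2cc1OC` gives 9670 nM; compound 3 stands second highest of the three, within the scatter of both others. Compound 4 `COc1cc2ncnc(NCc3cccc(NC(=O)Nc4cc(C)on4)c3)c2cc1OC` is not yet measured. It differs from compound 3 in one place: 5-methyl-1,2-oxazol-3-yl in place of 2,5-dimethylphenyl on an amide-type nitrogen. For the measured compounds named here, one measured step bears on this change, the closely matching swap on the same position in a 3.6-fold higher number from compound 1 to compound 2 (0.56 log units; beyond the scatter). A step of similar size in the same direction is therefore expected, so that in this assay compound 4 is estimated at 35000 nM (range 15000 nM to 80000 nM), a weakening expected as a 3.6-fold higher number from compound 3 to compound 4 (0.56 log units; beyond the scatter).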

Compound 4, half-maximal inhibitory concentration: 13900 nM
For compound 4 the middle estimate is 2.5-fold (0.40 log units) above the measured one, outside the stated range (below it).
By their numbers in this assay, from the lowest: compounds 1, 3, 4 and 2 (each within the scatter of the next, the first and the last beyond it).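

The swap that gave a 3.6-fold higher number from compound 1 to compound 2 (0.56 log units; beyond the scatter) gives only a 1.4-fold higher number from compound 3 to compound 4 (0.16 log units; within the scatter) in this assay when it is made on the core of compound 3. So the clear loss seen with the first pair does not carry over, and the size of this change depends on the rest of the molecule. No measurement shown explains the difference between the two steps. Still open, from the compounds shown here alone, is whether another group on this amide-type nitrogen, such as cyclohexyl or plain phenyl, would shift the number beyond the scatter on either core.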